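Propanoylamino in place of sulfamoyl: notes on the series

A few compounds are considered here, and "the series" means these few. Any claim that something is new, unique, unknown or untested is made for them only; others in the source may bear on it.

Measured in a toxicity assay on Huh-7.5 cells (Homo sapiens) for inhibition, read by MTT assay, with a stated time of 96 h; on this read-out lower numbers stand for higher toxicity in this test and higher numbers for lower toxicity in this test:
- compound 1 `CN1CCN(Cc2ccc(NC(=O)c3ccc(OCCCCl)c(S(N)(=O)=O)c3)cc2C(F)(F)F)CC1`: 5470 nM
- compound 2 `CN(C)C1CN(Cc2ccc(NC(=O)c3ccc(OCCCCl)c([N+](=O)[O-])c3)cc2C(F)(F)F)C1`: 7800 nM

Only these two numbers are available. In this assay, compound 1 gives 5470 nM and compound 2 gives 7800 nM, so the two lie within the usual scatter of each other. Among the compounds with values here, they differ in more than one place, so they offer no clean single-change step.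

The next compound to be measured is compound 3 `CCC(=O)Nc1cc(C(=O)Nc2ccc(CN3CCN(C)CC3)c(C(F)(F)F)c2)ccc1OCCCCl`. Relative to compound 1, it carries propanoylamino in place of sulfamoyl on an aromatic carbon, ortho to a 3-chloropropoxy group: propanoylamino in place of sulfamoyl on an aromatic carbon.

Within the data shown here, no measured step covers this exchange, so the expectation rests on the two values alone. With nothing pointing either way, no step beyond the scatter is expected in this assay, and no direction is favoured. The expected step is a 1.1-fold higher number from compound 1 to compound 3 (0.04 log units; within the scatter), which is an estimate and not a measurement. For compound 3 the expected value is 6000 nM, with an estimated range of 2500 nM to 15000 nM.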

Compound 3, half-maximal cytotoxic concentration: 7870 nM
Compound 3: middle estimate off by 1.3-fold (0.12 log units), on the low side; low and high end bracket the measured number.
By their numbers in this assay, from the lowest: compounds 1, 2 and 3 (each within the scatter of the next).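

Propanoylamino in place of sulfamoyl, on an aromatic carbon ortho to a 3-chloropropoxy group, supplies the first single-change step of the series: in this assay it gives a 1.4-fold higher number from compound 1 to compound 3 (0.16 log units; within the scatter) and stays within the usual scatter. At this position, the read-out therefore does not separate the two groups, even though the entering group has carbon atoms and no sulfur, and the counts of heavy atoms, double bonds and hydrogen-bond acceptors differ between them. This holds for this single pair only, with the rest of the core of compound 1 unchanged, and nothing available accounts for the result.

As far as these compounds go, whether a simple amine, a carboxylic acid or a longer acyl chain such as hexanoylamino at this same position would give a step beyond the scatter remains open. From the compounds shown here alone, it is also open whether the exchange of sulfamoyl for propanoylamino would read the same way with a different group on the other side of the shared core, as a single pair cannot show how general the result is.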